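The source may report more compounds than this note shows. Statements on the series, on what has been measured and on what is new or still open speak of the compounds shown alone.

In a functional assay on MCF7 cells (Homo sapiens) for antiproliferative activity, read by MTT assay, with a stated time of 72 h (on this read-out lower numbers stand for stronger inhibition and higher numbers for weaker inhibition), compound 1 `COc1cc(-n2ncnc2-c2ccccc2)cc(OC)c1OC` gives > 10000 nM, which is a limit of the assay and not a number. For the measured compounds named here, compound 2 `COc1cc(-n2ncnc2-c2ccc(OC(C)C)cc2)cc(OC)c1OC` gives 610 nM, the only true number measured so far. Going by the values given here, the one measured step, an at least 16-fold lower number from compound 1 to compound 2 (1.21 log units; beyond the scatter), is large and lies beyond the scatter, and it comes with isopropoxy in place of hydrogen on an aromatic carbon.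

Compound 3 `COc1cc(-n2ncnc2-c2ccc(SC)cc2)cc(OC)c1OC` changes the same place, para to a large group, with methylsulfanyl in place of isopropoxy on an aromatic carbon. Among the compounds with values here, the earlier step bears on this change only in part, since it compares a group with hydrogen, and no measurement yet compares two groups at this place. Compound 3 still carries a group there, so it is expected to keep most of the gain seen in an at least 16-fold lower number from compound 1 to compound 2 (1.21 log units; beyond the scatter), with no change beyond the scatter in this assay. The expected change is a 1.5-fold lower number from compound 2 to compound 3 (0.18 log units; within the scatter), and it remains uncertain. For compound 3 the estimate is 400 nM, with an expected range from 80 nM to 2500 nM.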

Compound 3, half-maximal inhibitory concentration: 390 nM
Compound 3: middle estimate off by 1.0-fold (0.01 log units), on the high side, within the range that was stated.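

The comparison of two groups at this place, on an aromatic carbon para to a large group, shows that in this assay methylsulfanyl in place of isopropoxy gives a 1.6-fold lower number from compound 2 to compound 3 (0.19 log units; within the scatter), so the two groups cannot be told apart here. Measured against hydrogen, methylsulfanyl gives an at least 25-fold lower number from compound 1 to compound 3 (1.40 log units; beyond the scatter), which shows that the large gain first seen with isopropoxy is not confined to that one group, and that a group of 2 heavy atoms, with sulfur in place of oxygen, is enough to bring it. The true size of that gain stays unknown because compound 1 stands at a limit and not at a number: the limit of > 10000 nM in this assay, at which 1 of the 3 values shown sits.

The compounds shown leave open how far this tolerance reaches, since a primary amine, a carboxylic acid or a longer alkoxy chain at this place might behave quite differently from these two neutral groups. They also leave open whether hydrogen is unusual in giving so weak a result, or whether a small group such as fluorine or methyl would already bring the gain.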